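The source may report more compounds than this note shows. Statements on the series, on what has been measured and on what is new or still open speak of the compounds shown alone.

Measured in a functional assay on the whole organism (stomach) with Canis familiaris (Canis lupus familiaris) as the target; on this read-out higher numbers stand for an effect only at larger amounts of compound and lower numbers for an effect already at smaller amounts:
- compound 1 `COC(=O)CC/C=C\CC[C@H]1C(=O)C[C@@H](O)[C@@H]1/C=C/C[C@@](C)(O)/C=C/C1=CCCCC1`: 0.0003 mg/kg
- compound 2 `COC(=O)CC/C=C\CC[C@H]1C(=O)C[C@@H](O)[C@@H]1/C=C/C[C@@](C)(O)/C=C/C1CC1`: 0.0001 mg/kg

Compound 2 holds the lower of the two numbers, at 0.0001 mg/kg. Compound 3 `COC(=O)CC/C=C\CC[C@H]1C(=O)C[C@@H](O)[C@@H]1/C=C/C[C@@](C)(O)/C=C/C1(C)CC1` differs from it in one place: methyl in place of hydrogen on a saturated ring carbon, which turns cyclopropyl to 1-methylcyclopropyl. For the measured compounds named here, the only measured guide is a 3.0-fold lower number from compound 1 to compound 2 (0.48 log units; beyond the scatter), a modest step that exchanged the whole group. For this smaller change, a shift in this assay beyond the scatter is not expected. The expected change is a 1.5-fold higher number from compound 2 to compound 3 (0.18 log units; within the scatter). Compound 3 is estimated at 0.00015 mg/kg, with an expected range of 0.00004 mg/kg to 0.0006 mg/kg.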

Compound 3, dose for half-maximal effect: 0.00002 mg/kg
Compound 3: the middle estimate sits 7.5-fold (0.88 log units) above what was measured; the measured number lies below the stated range.
By their numbers in this assay, from the lowest: compound 3; then compound 2; then compound 1.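

In this assay a single methyl on a saturated ring carbon of the three-membered ring is enough to move the number beyond the scatter, giving a 5.0-fold lower number from compound 2 to compound 3 (0.70 log units; beyond the scatter), so this position responds to a change far smaller than exchanging the whole group. Set against the cyclohex-1-en-1-yl group, 1-methylcyclopropyl gives a 15-fold lower number from compound 1 to compound 3 (1.18 log units; beyond the scatter), a large step. Nothing available here accounts for the effect of the methyl. From the compounds shown here alone, it remains open whether ethyl or trifluoromethyl on the same ring carbon would lower the number further or reverse the step.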